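Swapping 4-phenylphenyl for 2-chloropyridin-3-yl

This account rests on a few compounds, and the source may have more. Where it says the series, first, only, none or still open, it means among the compounds named here.

Measured so far in a functional assay on HepG2 cells (Homo sapiens) for inhibition, read by MTT assay, with a stated time of 24 h; on this read-out lower numbers stand for stronger inhibition and higher numbers for weaker inhibition

Compound 1 `Cc1ccc(C(=O)NCC(=O)N/N=C/c2ccccc2OCc2ccccc2Cl)cc1` gives 13400 nM
Compound 2 `COc1ccc(/C=N/NC(=O)CNC(=O)c2ccc(F)cc2)c(OCc2ccccc2Cl)c1` gives 15700 nM
Compound 3 `O=C(CNC(=O)c1ccc(-c2ccccc2)cc1)N/N=C/c1ccccc1OCc1ccccc1Cl` gives > 50000 nM as a limit of the assay

Compound 3 has no number, only a limit (the limit of > 50000 nM in this assay, at which 1 of the 3 values shown sits). Compound 4 `O=C(CNC(=O)c1cccnc1Cl)N/N=C/c1ccccc1OCc1ccccc1Cl` keeps the rest of compound 3 but, on a carbonyl carbon, carries 2-chloropyridin-3-yl in place of 4-phenylphenyl (2-chloropyridin-3-yl in place of 4-phenylphenyl on a carbonyl carbon).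

For the measured compounds named here, one measured step bears on this change: an at least 3.7-fold higher number from compound 1 to compound 3 (0.57 log units; beyond the scatter), with phenyl in place of methyl on an aromatic carbon. Compound 4 no longer has the 4-phenylphenyl group, so in this assay the step is expected to run toward a lower number, meaning stronger inhibition. Going by the values given here, how closely it would approach compound 1 at 13400 nM is uncertain, since no measured compound carries 2-chloropyridin-3-yl. The expected change is an at least 2.7-fold lower number from compound 3 to compound 4 (0.44 log units; beyond the scatter), which is only an estimate. For compound 4 the estimated value is 18000 nM, with an expected range from 7000 nM to 45000 nM.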

Compound 4, half-maximal inhibitory concentration: 16900 nM
Compound 4: middle estimate off by 1.1-fold (0.03 log units), on the high side, within the range that was stated.
By their numbers in this assay, from the lowest: compounds 1, 2 and 4 (each within the scatter of the next). At a limit, above all of these: compound 3.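

In this assay, putting 2-chloropyridin-3-yl in place of 4-phenylphenyl on the carbonyl carbon gives an at least 2.9-fold lower number from compound 3 to compound 4 (0.47 log units; beyond the scatter), so the weak result of compound 3 does not hold for every aromatic group at this place. Compound 3 has only a limit of the assay, not a number: the limit of > 50000 nM in this assay, at which 1 of the 4 values shown sits. Set against 4-methylphenyl, the same group gives a 1.3-fold higher number from compound 1 to compound 4 (0.10 log units; within the scatter), so these two groups cannot be told apart here, even though one carries a ring nitrogen and a chlorine and the other a methyl.

For the compounds shown here, whether the second phenyl ring of 4-phenylphenyl alone accounts for the weak result stays open, since only three groups on this carbonyl carbon can be compared over an otherwise identical structure. Going by these compounds, how an amine, a carboxylic acid or a longer alkyl chain on the aromatic ring would fare at this place also remains unknown.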